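A few compounds are considered here, and "the series" means these few. Any claim that something is new, unique, unknown or untested is made for them only; others in the source may bear on it.

Working notes on the series. The shared core carries a group on an aromatic carbon of a five-membered aromatic ring with 4 nitrogen, and this group is what is varied.

Compound 1 `CCCCCCCCc1ccc(OCC(=O)Cn2nnc(-c3cccc(Cl)c3)n2)cc1` stands highest of the two numbers measured in an ADME assay on S9 fraction from liver (Rattus norvegicus) for metabolic stability, read by LC-MS, using NADPH, with a stated time of 30 min (a higher number here means that more of the compound is left, a lower number that less of the compound is left), where compound 1 gives 69%. Compound 2 `CCCCCCCCc1ccc(OCC(=O)Cn2nnc(-c3ccccn3)n2)cc1` carries pyridin-2-yl in place of 3-chlorophenyl on an aromatic carbon; in this assay compound 2 gives 30%, a step of a number 39 percentage points lower from compound 1 to compound 2 (beyond the scatter).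

Compound 3 `CCCCCCCCc1ccc(OCC(=O)Cn2nnc(-c3cccs3)n2)cc1` is not yet measured in this assay. Against compound 1 it shows (thiophen-2-yl in place of 3-chlorophenyl on an aromatic carbon). Among the compounds with values here, the only measured step that bears on it is the exchange of 3-chlorophenyl for a different aromatic group, a number 39 percentage points lower from compound 1 to compound 2 (beyond the scatter), which was large. Thiophen-2-yl is neither of the two measured groups, so the direction is read from that single step only, with wide uncertainty. A downward step of moderate size is therefore expected, a number 19 percentage points lower from compound 1 to compound 3 (beyond the scatter). For compound 3 in this assay the estimate is 50%, with a range from 25% to 75%.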

Compound 3, percent of the compound remaining: 8%
The estimate for compound 3 lay 42 percentage points above the measured number; measured number outside the range, below it.
By their numbers in this assay, from the lowest: compound 3; then compound 2; then compound 1.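

Thiophen-2-yl on this aromatic carbon gives the lowest number of the three in this assay: a number 61 percentage points lower from compound 1 to compound 3 (beyond the scatter), and a number 22 percentage points lower from compound 2 to compound 3 (beyond the scatter). The fall on leaving 3-chlorophenyl is therefore not confined to pyridin-2-yl, and the two groups now tested in its place differ from each other beyond the scatter, so the number depends on which aromatic group sits here and not merely on the loss of 3-chlorophenyl. Nothing available explains this order of the three groups.

The compounds shown leave open whether the higher number of compound 1 goes with the chlorine or with the six-membered ring of carbon only, a question that an unsubstituted phenyl or a 3-fluorophenyl group at this position would address. Also open, going by these compounds, is how far the octyl chain, common to all three compounds, sets the level of these numbers, which a shorter chain such as butyl on the shared core would test.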